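The compounds below may be only part of what the source reports. "The series", "measured", "known", "first", "only" and "open" are said of these compounds alone.

Measured in a functional assay on A2780 cells (Homo sapiens) for antiproliferative activity, read by MTT assay, with a stated time of 48 h; on this read-out higher numbers stand for weaker inhibition and lower numbers for stronger inhibition:
- Compound 1 `CCNC(=O)Nc1nc(-c2ccc(OCC)cc2)c(-c2cc(OC)c(OC)c(OC)c2)s1`: 1.3 nM
- Compound 2 `CCOc1ccc(-c2nc(N(Cc3ccccc3)Cc3ccccc3)sc2-c2cc(OC)c(OC)c(OC)c2)cc1`: > 5000 nM (a limit of the assay)

For the measured compounds named here, compound 1 holds the only actual number in this assay, so it cannot be ranked against a second measured value. The reading for compound 2 is a limit, > 5000 nM.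

Compound 3 `CCOc1ccc(-c2nc(NS(=O)(=O)c3ccc(OC)c(F)c3)sc2-c2cc(OC)c(OC)c(OC)c2)cc1` has not yet been measured. It carries (3-fluoro-4-methoxyphenyl)sulfonyl in place of ethylcarbamoyl on a nitrogen on an aromatic ring.

Going by the values given here, no measured step bears directly on this exchange. Weaker inhibition is nevertheless expected in this assay, by a large but uncertain margin, since compound 1 at 1.3 nM leaves little room for improvement. The expected change is a 150-fold higher number from compound 1 to compound 3 (2.19 log units; beyond the scatter). For compound 3 the estimated value is 200 nM, with an expected range of 10 nM to 4000 nM.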

Compound 3, half-maximal inhibitory concentration: > 5000 nM
Compound 3: a limit, no number; the forecaster's own chance of this, stated with the estimate: 25%; at least 25-fold (1.39 log units) between middle value and limit.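

In this assay, for the compounds shown here, the step from ethylcarbamoyl to (3-fluoro-4-methoxyphenyl)sulfonyl on a nitrogen on an aromatic ring is an at least 3800-fold higher number from compound 1 to compound 3 (3.58 log units; beyond the scatter), the first single exchange at this position that can be read. It shows that the low nanomolar activity of compound 1 does not survive this change, even though the rest of the molecule stays the same. Compound 3 gives only a limit of the assay, so the step has a floor but no true size: the limit of > 5000 nM in this assay, at which 2 of the 3 values shown sit.

The compounds shown leave open whether the loss follows from the sulfonyl link or from the aromatic ring it carries, a question that a methylsulfonyl or a benzoyl group on this nitrogen would address. As far as these compounds go, how a free amine or a longer alkyl chain on the carbamoyl group would fare also remains open.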